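The compounds below may be only part of what the source reports. "The series", "measured", "known", "first", "only" and "open" are said of these compounds alone.

In an ADME assay on microsomes from liver (Mus musculus) for metabolic stability, read by LC-MS, with a stated time of 10 min, tested at 0.5 uM (a lower number here means that less of the compound is left, a higher number that more of the compound is left), three measured compounds share one core and differ in the chain attached to it. Compound 1 `c1ccc2c(c1)CN[C@@H](CN(CCN1CCNCC1)[C@H]1CCCc3cccnc31)C2` gives 79%, compound 2 `NC(=O)N1CCN(CCCN(C[C@H]2Cc3ccccc3CN2)[C@H]2CCCc3cccnc32)CC1` gives 42%, and compound 3 `CN1CCN(CCCN(C[C@H]2Cc3ccccc3CN2)[C@H]2CCCc3cccnc32)CC1` gives 53%, the middle of the three numbers. Compound 4 `c1ccc2c(c1)CN[C@@H](CN(CCCCN1CCNCC1)[C@H]1CCCc3cccnc31)C2` has not been measured yet. It has the same atoms as compound 3, joined differently: (piperazin-1-yl)methyl in place of 4-methylpiperazin-1-yl on a saturated chain carbon, three bonds along the chain from an amine nitrogen. Its chain ends in an unsubstituted piperazin-1-yl group, as in compound 1, but is longer, as 4-(piperazin-1-yl)butyl.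

Among the compounds with values here, three measured steps bear on this. The step of a number 26 percentage points lower from compound 1 to compound 3 (beyond the scatter) is modest, and the step of a number 37 percentage points lower from compound 1 to compound 2 (beyond the scatter) is large. The step of a number 11 percentage points higher from compound 2 to compound 3 (beyond the scatter) is modest and changes only the group on the ring nitrogen. Within the data shown here, each of the first two steps changes the chain length and the ring substituent together, and no measured compound has the butyl chain, so the separate contribution of each is unknown. Compound 4 may therefore recover only part of the gap to compound 1. The expected change is a modest rise, a number 12 percentage points higher from compound 3 to compound 4 (beyond the scatter). For compound 4 the estimated value is 65%, with an expected range from 47% to 80%.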

Compound 4, percent of the compound remaining: 96%
For compound 4 the middle estimate is 31 percentage points below the measured one; the measured number lies above the stated range.
By their numbers in this assay, from the lowest: compound 2; then compound 3; then compound 1; then compound 4.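

In this assay the chain ending in unsubstituted piperazin-1-yl can grow to 4-(piperazin-1-yl)butyl without any loss, with a number 17 percentage points higher from compound 1 to compound 4 (beyond the scatter) as the result. Keeping the same atoms but moving the methyl from the ring nitrogen into the chain gives a number 43 percentage points higher from compound 3 to compound 4 (beyond the scatter) as a large change from a mere rearrangement. With a number 54 percentage points higher from compound 2 to compound 4 (beyond the scatter) as well, both compounds with an unsubstituted piperazine now stand above both compounds with a substituted one, and none of the four goes against this.

The steps to compound 4 from compounds 2 and 3 still change chain length and ring nitrogen group together, so a 3-(piperazin-1-yl)propyl chain or a 4-(4-methylpiperazin-1-yl)butyl chain would be needed to separate their shares. Nothing available here gives a reason for these numbers.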